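Replacing a chlorophenyl with a benzyl on a pyrazole core

A few compounds are considered here, and "the series" means these few. Any claim that something is new, unique, unknown or untested is made for them only; others in the source may bear on it.

Measured so far:
compound 1, `CS(=O)(=O)NC(=O)CCc1cn(-c2ccc(Br)cc2)nc1-c1ccc(Cl)cc1`: 170000 nM
compound 2, `CS(=O)(=O)NC(=O)CCc1cn(-c2ccccc2)nc1-c1ccc(Cl)cc1`: 200000 nM
compound 3, `CS(=O)(=O)NC(=O)CCc1cn(C2CCCCC2)nc1-c1ccc(Cl)cc1`: 200000 nM

Of the compounds shown here, three share a core and have been tested in a physicochemical assay for solubility, in phosphate buffer, measured as thermodynamic solubility, at pH 7.4; on this read-out higher numbers stand for higher solubility and lower numbers for lower solubility. In this assay compound 1 gives 170000 nM, the lowest of the three numbers, but its neighbours sit close: a 1.2-fold higher number from compound 1 to compound 2 (0.07 log units; within the scatter) and a 1.2-fold higher number from compound 1 to compound 3 (0.07 log units; within the scatter). The step of no change at the digits printed from compound 2 to compound 3 (within the scatter) is equally flat. All three measured steps vary only the group on the aromatic nitrogen, and none of them moves the read-out beyond the scatter.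

Compound 4, `CS(=O)(=O)NC(=O)CCc1cn(-c2ccc(Br)cc2)nc1Cc1ccccc1`, has not been measured. It differs from compound 1 at the aromatic carbon of the core: benzyl in place of 4-chlorophenyl on an aromatic carbon. For the measured compounds named here, no measured step touches this place, so the three flat steps bear on it only indirectly, by showing that the solubility of this series has so far been insensitive to changes of a ring substituent. On that basis no step beyond the scatter is expected in this assay, in either direction.

Compound 4 is therefore estimated at 200000 nM, with a range from 90000 nM to 450000 nM; the expected step is a 1.2-fold higher number from compound 1 to compound 4 (0.07 log units; within the scatter).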

Compound 4, solubility: 200000 nM
Beside the measured number, compound 4's estimate shows no gap at the digits printed; measured number inside the range.
By their numbers in this assay, from the lowest: compounds 1, 2, 3 and 4 (each within the scatter of the next).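

In this assay, benzyl in place of 4-chlorophenyl on an aromatic carbon of the shared core gives a 1.2-fold higher number from compound 1 to compound 4 (0.07 log units; within the scatter), the only step shown at this place. The earlier steps shown here all varied the group on the aromatic nitrogen, so the flat read-out now extends to a second place on the core, and none of the four compounds goes against it. The swap removes the chlorine while keeping a six-membered aromatic ring of carbon only, but nothing here explains why the read-out stays level.

Going by these compounds, this single step compares two groups that both carry such a ring, so it remains open whether an amine, a carboxylic acid or a longer chain ending in a phenyl ring on this carbon would also stay within the scatter. On these data alone, the 2-((methylsulfonyl)carbamoyl)ethyl group is the same in all four compounds, so the read-out's response to a change there, such as a plain carboxylic acid in its place, also remains open.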